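Chloro for hydrogen on the aryl ester of compound 3

A few compounds are considered here, and "the series" means these few. Any claim that something is new, unique, unknown or untested is made for them only; others in the source may bear on it.

Compound 3 `CCOC(=O)/C=C/c1ccccc1OC(=O)c1nc(C)c(C)nc1C` gives 36.9% in a functional assay on EA.hy 926 cells (Homo sapiens) for cytotoxicity, read by MTT assay, with stated times of 24 h and 12 h, tested at 50 uM (a higher number here means a stronger effect of the compound at the concentration tested, a lower number a weaker effect), the highest of the three numbers shown. Compound 1 `CCOC(=O)/C=C/c1cc(OC)ccc1OC(=O)c1nc(C)c(C)nc1C` gives 27.8%, and the step of a number 9.1 percentage points higher from compound 1 to compound 3 (within the scatter) lies within the scatter. Compound 2 `Cc1nc(C)c(C(=O)Oc2ccc(Cl)cc2/C=C/C(=O)O)nc1C` gives 23.7%, a gap beyond the scatter, though it differs from compound 3 in more than one place. Compound 4 `CCOC(=O)/C=C/c1cc(Cl)ccc1OC(=O)c1nc(C)c(C)nc1C` carries chloro in place of hydrogen on an aromatic carbon. Among the compounds with values here, only one measured step touches that carbon, the exchange of methoxy for hydrogen from compound 1 to compound 3, and it stayed within the scatter; compound 2 also bears a chloro there but no single step to it exists. Compound 4 is therefore expected to sit near compound 3, with a step of a number 5.9 percentage points lower from compound 3 to compound 4 (within the scatter) in this assay, an estimate of 31% spanning 19% to 43%.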

Compound 4, a percentage reported as activity, at one concentration (the size of the read-out at that concentration, not a potency): 33.7%
For compound 4 the middle estimate is 2.7 percentage points below the measured one, within the range that was stated.
By their numbers in this assay, from the lowest: compounds 2, 1, 4 and 3 (each within the scatter of the next, the first and the last beyond it).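

In this assay, the aromatic carbon para to a large group now has hydrogen, methoxy and chloro compared directly, and neither step involving chloro leaves the scatter: a number 3.2 percentage points lower from compound 3 to compound 4 (within the scatter) and a number 5.9 percentage points higher from compound 1 to compound 4 (within the scatter) in this series. The change of hydrogen to ethyl on an oxygen next to a carbonyl group, a number 10 percentage points higher from compound 2 to compound 4 (within the scatter), also stays within the scatter. No independent measurement bears on these steps.

From the compounds shown here alone, an amine on that aromatic carbon, or a longer chain in place of the ethyl, remains open.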